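A few compounds are considered here, and "the series" means these few. Any claim that something is new, unique, unknown or untested is made for them only; others in the source may bear on it.

Measured so far in an ADME assay on J774 cells (Mus musculus, strain BALB/c) for cytotoxicity, read by resazurin assay, with a stated time of 72 h; on this read-out higher numbers stand for lower toxicity in this test and lower numbers for higher toxicity in this test:
- compound 1 `CC(/C=N/Nc1ccc([N+](=O)[O-])cc1)=N\NC(=O)c1ccccc1Nc1ccccc1` gives > 100000 nM, a limit of the assay.
- compound 2 `CC(/C=N/Nc1ccc([N+](=O)[O-])cc1)=N\NC(=O)c1ccccc1N` gives 29800 nM.
- compound 3 `COc1cc(C(=O)N/N=C(C)/C=N/Nc2ccc([N+](=O)[O-])cc2)ccc1O` gives > 100000 nM, a limit of the assay.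

Compound 3 therefore stands at the top of the numbers shown, not at a number of its own; (the limit of > 100000 nM in this assay, at which 2 of the 3 values shown sit). Compound 4 `CC(/C=N/Nc1ccc([N+](=O)[O-])cc1)=N\NC(=O)c1ccccc1I` differs from compound 3 by 2-iodophenyl in place of 4-hydroxy-3-methoxyphenyl on a carbonyl carbon. Among the measured compounds shown here, the one measured step at the same place is an at least 3.3-fold higher number from compound 2 to compound 3 (0.52 log units; beyond the scatter), which ends at the limit; the other, an at least 3.3-fold lower number from compound 1 to compound 2 (0.52 log units; beyond the scatter), sits on a nitrogen on an aromatic ring and bears only loosely on this change. Both steps were at least modest. From a starting limit, the step expected for compound 4 is an at least 1.6-fold lower number from compound 3 to compound 4 (0.22 log units; that floor lies within the scatter), in this assay. Compound 4 is estimated at 60000 nM, between 20000 nM and 150000 nM, with a real chance of only a limit again.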

Compound 4, half-maximal cytotoxic concentration: 40000 nM
The estimate for compound 4 lay 1.5-fold (0.18 log units) above the measured number; measured number inside the range.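

On a carbonyl carbon, 2-iodophenyl in place of 4-hydroxy-3-methoxyphenyl gives an at least 2.5-fold lower number from compound 3 to compound 4 (0.39 log units; beyond the scatter) and so shows that a group other than 2-aminophenyl also brings the read-out off the limit. Iodo in place of amino on an aromatic carbon gives a 1.3-fold higher number from compound 2 to compound 4 (0.13 log units; within the scatter) and does not tell the two groups apart, while iodo in place of anilino gives an at least 2.5-fold lower number from compound 1 to compound 4 (0.39 log units; beyond the scatter) as a further step off the limit. Compound 1 and compound 3 are limits, so the steps from them are floors only: the limit of > 100000 nM in this assay, at which 2 of the 4 values shown sit.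

Open, going by these compounds, is how a bromo group or a carboxylic acid on that aromatic carbon would read against compound 2 and compound 4.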